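The source may hold more compounds than are shown below. What is called first, only, known or untested is meant among the compounds shown, and "the series" means these compounds.

For the measured compounds named here, compound 3 `CCC(=O)N1N=C(C)CC1c1cc(Br)cc(Br)c1O` gives 28600 nM in a functional assay on PC-3 cells (Homo sapiens) for cytotoxicity, read by MTT assay, with a stated time of 48 h (a lower number here means a stronger inhibitor, a higher number a weaker inhibitor), and stands second highest of the three numbers known so far, with compound 1 `CCC(=O)N1N=C(C)CC1c1cc(Br)ccc1O` giving 37800 nM and compound 2 `CC1=NN(C(=O)CCc2ccccc2)C(c2cc(Br)ccc2O)C1` giving 16300 nM. Compound 4 `CC1=NN(C(=O)CCc2ccccc2)C(c2cc(Br)cc(Br)c2O)C1` differs from compound 3 by phenyl in place of hydrogen on a saturated chain carbon, two bonds along the chain from a carbonyl carbon. The same change has been made once before on a close relative: a 2.3-fold lower number from compound 1 to compound 2 (0.37 log units; beyond the scatter), a modest step beyond the scatter. The other known step, a 1.3-fold lower number from compound 1 to compound 3 (0.12 log units; within the scatter), lies within the scatter and adds nothing on this change. Carrying the ethyl-to-phenethyl step over to compound 3, a similar modest fall in the number is expected, so compound 4 is estimated at 13000 nM, with a range from 6000 nM to 30000 nM, which amounts to an expected 2.2-fold lower number from compound 3 to compound 4 (0.34 log units; beyond the scatter).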

Compound 4, half-maximal inhibitory concentration: 11300 nM
Estimate against measurement, compound 4: 1.2-fold (0.06 log units) above, within the range that was stated.
By their numbers in this assay, from the lowest: compounds 4, 2, 3 and 1 (each within the scatter of the next, the first and the last beyond it).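

The ethyl-to-phenethyl change now repeats on a second core, with a 2.5-fold lower number from compound 3 to compound 4 (0.40 log units; beyond the scatter) in this assay, so the earlier fall was not peculiar to compound 2: the same change on two cores in this assay, a 2.3-fold lower number (0.37 log units; beyond the scatter) from compound 1 to compound 2 and a 2.5-fold lower number (0.40 log units; beyond the scatter) from compound 3 to compound 4, 1.1-fold (0.04 log units) apart, within the scatter of two such steps. The bromo change stays small on the phenethyl core as well, with a 1.4-fold lower number from compound 2 to compound 4 (0.16 log units; within the scatter), and it matches its earlier size: the same change on two cores in this assay, a 1.3-fold lower number (0.12 log units; within the scatter) from compound 1 to compound 3 and a 1.4-fold lower number (0.16 log units; within the scatter) from compound 2 to compound 4, 1.1-fold (0.04 log units) apart, within the scatter of two such steps.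

Going by these compounds, what a longer chain ending in phenyl, or a phenyl carrying an amine, would do at this position remains open. So does whether the aromatic ring itself matters, which a cyclohexyl group in its place could test.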